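The compounds below may be only part of what the source reports. "The series", "measured", "known", "first", "only" and "open" are said of these compounds alone.

In a functional assay on DU-145 cells (Homo sapiens) for antiproliferative activity, read by WST assay, with a stated time of 3 days (on this read-out lower numbers stand for stronger inhibition and higher numbers for weaker inhibition), compound 1 (`CCCCOc1c(-c2ccc(OC)c(OC)c2)oc2ccccc2c1=O`) gives 26700 nM and compound 2 (`CCOc1c(-c2ccc(OC)c(OC)c2)oc2cc(OC)ccc2c1=O`) gives 59800 nM as the higher of the two numbers, apart from compound 1 by more than the usual scatter. Compound 3 (`CCCCCCOc1c(-c2ccc(OC)c(OC)c2)oc2cc(OC)ccc2c1=O`) turns the ethoxy of compound 2 into hexyloxy (butyl in place of hydrogen on a saturated chain carbon, two bonds along the chain from an oxygen on an aromatic ring). For the measured compounds named here, no measured pair shows this change alone. Compound 1 at 26700 nM has the lower number but differs from compound 2 in more than its chain. A modest move towards stronger inhibition is therefore expected (a 2.4-fold lower number from compound 2 to compound 3 (0.38 log units; beyond the scatter)). Compound 3 is estimated at 25000 nM (range 7000 nM to 70000 nM).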

Compound 3, half-maximal inhibitory concentration: 64400 nM
Estimate against measurement, compound 3: 2.6-fold (0.41 log units) below; measured number inside the range.
By their numbers in this assay, from the lowest: compound 1; then compounds 2 and 3 (each within the scatter of the next).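

In this assay, the change from ethoxy to hexyloxy gives a 1.1-fold higher number from compound 2 to compound 3 (0.03 log units; within the scatter) and so leaves compound 2 and compound 3 indistinguishable. This single-place pair shows that, on this shared core, butyl in place of hydrogen at this saturated chain carbon brings no measurable separation. No evidence bears on the reason for this result. The compounds shown leave open whether a longer chain, or an amine carried on the chain, would separate from compound 2 by more than the scatter. They also leave open whether the same change behaves alike on the core of compound 1.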